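From 2-Fluorophenyl to 4-Fluorophenyl in a Cytotoxic Series

The source may report more compounds than this note shows. Statements on the series, on what has been measured and on what is new or still open speak of the compounds shown alone.

In a functional assay on CWR22R cells (Homo sapiens) for cytotoxicity, read by MTT assay, with a stated time of 72 h (a lower number here means a stronger inhibitor, a higher number a weaker inhibitor), compound 1 (`CC1=C(/C=C/C(=O)/C=C/c2ccccc2C(F)(F)F)C(C)(C)CCC1O`) gives 2300 nM and compound 2 (`CC1=C(/C=C/C(=O)/C=C/c2ccccc2F)C(C)(C)CCC1O`) gives 3300 nM. Within the data shown here, compound 2 therefore stands within the scatter of the only other measured compound, and the two numbers cannot be ranked. The next compound, compound 3 (`CC1=C(/C=C/C(=O)/C=C/c2ccc(F)cc2)C(C)(C)CCC1O`), keeps the shared core and differs in one place: 4-fluorophenyl in place of 2-fluorophenyl on a double-bonded chain carbon bound to a double-bonded chain carbon. The same atoms are present, and only the place of the fluoro group on the aromatic ring changes.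

Among the measured compounds shown here, only one measured step bears on this change, and it does so indirectly. That step, a 1.4-fold higher number from compound 1 to compound 2 (0.16 log units; within the scatter), put fluoro in place of trifluoromethyl on an aromatic carbon and stayed within the scatter. For the measured compounds named here, no measured pair compares two places of the fluoro group, so the data offer no direct precedent. Going by the values given here, with that single small step as the only guide, no change beyond the scatter is expected in this assay. The expected step is a 1.1-fold lower number from compound 2 to compound 3 (0.04 log units; within the scatter). The estimated value for compound 3 is 3000 nM, with an expected range from 1300 nM to 7000 nM.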

Compound 3, half-maximal inhibitory concentration: 7500 nM
Estimate against measurement, compound 3: 2.5-fold (0.40 log units) below; measured number above the stated range.
By their numbers in this assay, from the lowest: compounds 1 and 2 (each within the scatter of the next); then compound 3.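

In this assay, among these compounds, the change gives a 2.3-fold higher number from compound 2 to compound 3 (0.36 log units; beyond the scatter) and is the first step in this set to lie beyond the scatter, though only modestly. The earlier step, a 1.4-fold higher number from compound 1 to compound 2 (0.16 log units; within the scatter), exchanged one group on the ring for another and could not be read as a change, whereas this one shows that with the same atoms present, the place of the fluoro group alone can move the number, with 4-fluorophenyl giving the weaker result of the pair. No measurement offered here accounts for the difference between 2-fluorophenyl and 4-fluorophenyl.

The compounds shown leave open whether this difference belongs to fluoro alone or would also appear with another group, since trifluoromethyl is seen only in compound 1 and no pair compares two places of that group. From the compounds shown here alone, it also remains open whether a plain phenyl group, with no fluoro on it, would read closer to compound 2 or to compound 3, and whether a methoxy group or an amine on the ring would follow the same direction.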